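Replacing 3,5-dimethylphenyl with 4-methoxyphenyl

The compounds below may be only part of what the source reports. "The series", "measured", "known", "first", "only" and "open" are said of these compounds alone.

Three close relatives have been measured in a functional assay on A2780 cells (Homo sapiens) for cytotoxicity, read by MTT assay, with a stated time of 72 h (a higher number here means a weaker inhibitor, a lower number a stronger inhibitor), and differ only in one aromatic group. Compound 1 `Cc1cc(C)cc(C(=O)N(CCCCCC(=O)Nc2ccccc2N)CC(=O)NCc2ccccc2)c1` carries plain phenyl there, with 20900 nM as its value. Compound 2 `Cc1ccc(CNC(=O)CN(CCCCCC(=O)Nc2ccccc2N)C(=O)c2cc(C)cc(C)c2)cc1` carries 4-methylphenyl, with 9800 nM as its value, and compound 3 `Cc1cc(C)cc(CNC(=O)CN(CCCCCC(=O)Nc2ccccc2N)C(=O)c2cc(C)cc(C)c2)c1` carries 3,5-dimethylphenyl, with 5100 nM as its value. Compound 3 shares the low end of this small set with compound 2. That pair is separated by only a 1.9-fold lower number from compound 2 to compound 3 (0.28 log units; within the scatter) as the step. Both stand clear of the phenyl compound, with a 2.1-fold lower number from compound 1 to compound 2 (0.33 log units; beyond the scatter) and a 4.1-fold lower number from compound 1 to compound 3 (0.61 log units; beyond the scatter) as the two steps.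

The change to compound 4 `COc1ccc(CNC(=O)CN(CCCCCC(=O)Nc2ccccc2N)C(=O)c2cc(C)cc(C)c2)cc1`, not yet measured, reads 4-methoxyphenyl in place of 3,5-dimethylphenyl on a saturated chain carbon bound to an amide-type nitrogen and puts 4-methoxyphenyl in place of 3,5-dimethylphenyl on a saturated chain carbon bound to an amide-type nitrogen. Going by the values given here, no measured compound carries a methoxy group, so the closest guide is compound 2, with its 4-methylphenyl and 9800 nM as its value. The measured steps are all modest or smaller, so only a small move towards a higher number is expected in this assay here. The estimated step is a 1.8-fold higher number from compound 3 to compound 4 (0.25 log units; within the scatter) and would not be a large one. For compound 4 the expected value is 9000 nM with 4000 nM as the estimated lower end and 20000 nM as the upper end.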

Compound 4, half-maximal inhibitory concentration: 24600 nM
The estimate for compound 4 lay 2.7-fold (0.44 log units) below the measured number, outside the stated range (above it).
By their numbers in this assay, from the lowest: compounds 3 and 2 (each within the scatter of the next); then compounds 1 and 4 (each within the scatter of the next).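

In this assay, this position does not respond to just any added group on the ring: methoxy in place of methyl separates compound 2 and compound 4, with a 2.5-fold higher number from compound 2 to compound 4 (0.40 log units; beyond the scatter) as the step. Methoxy in place of hydrogen, by contrast, leaves compound 4 indistinguishable from the plain phenyl compound, with a 1.2-fold higher number from compound 1 to compound 4 (0.07 log units; within the scatter) as the step, so the lower numbers seen so far do not extend to every substituted ring. Going by these compounds alone, the full change from 3,5-dimethylphenyl to 4-methoxyphenyl gives a 4.8-fold higher number from compound 3 to compound 4 (0.68 log units; beyond the scatter) as its step, which shows that the two methyl groups of compound 3 and the single methoxy group of compound 4 are far from interchangeable here, even though the two groups have the same heavy-atom count.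

As far as these compounds go, it remains open how a 3,5-dimethoxyphenyl group, which would keep the pattern of compound 3 while carrying methoxy, or a 4-chlorophenyl group would behave at this position. The data shown include no measurement that explains why methoxy and methyl differ here.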